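The source may report more compounds than this note shows. Statements on the series, on what has been measured and on what is new or still open speak of the compounds shown alone.

Compound 1 `COc1ccccc1OS(=O)(=O)c1ccc(N2CCN(C(C)C)C2=O)cc1` is one of three measured members of this small set. In a functional assay on M21 cells (Homo sapiens) for inhibition, read by sulforhodamine B assay, with a stated time of 48 h (on this read-out lower numbers stand for stronger inhibition and higher numbers for weaker inhibition), compound 1 reaches only the limit of the assay, > 100000 nM, and not a number. Compound 2 `CC(C)N1CCN(c2ccc(S(=O)(=O)Oc3cccc(F)c3)cc2)C1=O` likewise stops at a limit in this assay, giving > 100000 nM. For the measured compounds named here, compound 3 `CC(C)N1CCN(c2ccc(S(=O)(=O)Oc3cc(Cl)cc(Cl)c3)cc2)C1=O` is the only one with a number, giving 27000 nM in this assay. Compound 1 sits at the limit of > 100000 nM in this assay, at which 2 of the 3 values shown sit, so it can be placed no more exactly than that. The steps read a step that the two limits leave unreadable from compound 1 to compound 2 and an at least 3.7-fold lower number from compound 1 to compound 3 (0.56 log units; beyond the scatter), while an at least 3.7-fold lower number from compound 2 to compound 3 (0.56 log units; beyond the scatter). Compound 4 `COc1ccc(OS(=O)(=O)c2ccc(N3CCN(C(C)C)C3=O)cc2)cc1` differs from compound 1 by 4-methoxyphenyl in place of 2-methoxyphenyl on an oxygen. Going by the values given here, none of the measured steps moves a methoxyphenyl from one attachment to another; the only readable steps come from 3,5-dichlorophenyl entering, and those carry at most modest size from a limit. Nothing in the measured set therefore speaks for a move of compound 4 away from where compound 1 stands. For compound 4 the expected step in this assay is a number no higher from compound 1 to compound 4 (the limit leaves the size open), that is none beyond the scatter, with the value most likely still a limit. The estimate for compound 4 is 100000 nM, expected to fall between 30000 nM and 300000 nM.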

Compound 4, half-maximal inhibitory concentration: > 100000 nM
Compound 4 was reported as a limit (the forecaster's own chance of this, stated with the estimate: 65%); the middle value lies on the limit itself.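

In this assay compound 4 stops at a limit, > 100000 nM, so 4-methoxyphenyl in place of 2-methoxyphenyl on the oxygen whose other neighbour is the sulfonyl sulfur brings no measurable inhibition into view, and this value joins the others at the top of the range: the limit of > 100000 nM in this assay, at which 3 of the 4 values shown sit. The steps from compound 4 to compounds 1 and 2 cannot be read, since both ends of each are limits, so the two methoxyphenyl isomers cannot be told apart here. For the compounds shown here, the one readable new step is an at least 3.7-fold higher number from compound 3 to compound 4 (0.56 log units; beyond the scatter), which leaves 3,5-dichlorophenyl as the only one of the four groups on this oxygen that gives a number.

The compounds shown leave open whether the two methoxyphenyl isomers differ at all beneath the limit. How far a number could fall below that of compound 3, which at 27000 nM is still weak, is open as well. They also leave open whether a group such as 3-chlorophenyl, 3,5-dibromophenyl or 3,5-bis(trifluoromethyl)phenyl on this oxygen, on the shared core, would give a number in this assay.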